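From Compound 2 to Compound 3 on Vero Cells

The compounds below may be only part of what the source reports. "The series", "measured", "known", "first", "only" and "open" are said of these compounds alone.

Compound 1 `COc1ccc(C(=O)Nc2cc3nc(C4CCCCC4)[nH]c3cc2N2CCCC2)cc1`: > 100 ug/mL
Compound 2 `CCCOCC(=O)Nc1cc2nc(C3CCCCC3)[nH]c2cc1N1CCCC1`: > 100 ug/mL

In an ADME assay on Vero cells (Chlorocebus sabaeus) for cytotoxicity, read by resazurin assay, with a stated time of 3 days (a higher number here means a weaker inhibitor, a lower number a stronger inhibitor), compound 1 gives > 100 ug/mL, and that reading is a limit of the assay rather than a number. In this assay compound 2 gives > 100 ug/mL, which is likewise a limit. Compound 2 thus stands at the limit, where both values sit (the limit of > 100 ug/mL in this assay, at which 2 of the 2 values shown sit). Among the compounds with values here, the only measured step, a step that the two limits leave unreadable from compound 1 to compound 2, lies between two limits, so its size cannot be read. Compound 3 `COCCOC(=O)Nc1cc2nc(C3CCCCC3)[nH]c2cc1N1CCCC1` is not yet measured in this assay; it differs from compound 2 by 2-methoxyethoxy in place of propoxymethyl on a carbonyl carbon. Within the data shown here, the one measured step concerns the same carbonyl carbon yet offers no size, so no movement beyond the scatter can be foreseen in either direction. Compound 3 is therefore expected to sit at the limit as well, at 150 ug/mL (between 60 ug/mL and 400 ug/mL). The expected step that the limit leaves unreadable from compound 2 to compound 3 is accordingly essentially none.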

Compound 3, half-maximal inhibitory concentration: > 100 ug/mL
Compound 3: only a limit was reported (the forecaster's own chance of this, stated with the estimate: 85%); the middle value does not contradict the limit.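

No step among compound 1, compound 2 and compound 3 can be read in this assay, since each reading is a limit of the assay and not a number: the limit of > 100 ug/mL in this assay, at which 3 of the 3 values shown sit.

The compounds shown leave open whether any of these groups on the carbonyl carbon changes the reading in this assay, and by how much.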